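Trifluoromethyl for methyl on the urea aryl of compound 1

The compounds below may be only part of what the source reports. "The series", "measured", "known", "first", "only" and "open" are said of these compounds alone.

Compound 1, `CNc1cc(Oc2ccc(NC(=O)Nc3cccc(C)c3)cc2)ncn1`, is the starting point of this account. In an assay on isolated protein for inhibition of serine/threonine-protein kinase TNNI3K (Homo sapiens) (a lower number here means a stronger inhibitor, a higher number a weaker inhibitor), compound 1 gives 1260 nM, the highest of the two numbers recorded here; its nearest neighbour, compound 3, lies far lower, beyond the scatter. Compound 3, `CNc1cc(Oc2ccc(NC(=O)Nc3cccc(C(F)(F)F)c3)c(F)c2F)ncn1`, carries a trifluoromethyl on the aryl of the urea and two fluorines on the central ring, and in this assay compound 3 gives 20 nM. Compound 2, `CCc1cc(NC(=O)Nc2cccc(C(F)(F)F)c2)cc(Cl)c1Oc1cc(NC)ncn1`, differs in several places at once. For compound 2 this assay reports only a limit, <= 10 nM, and the limit of <= 10 nM in this assay, at which 1 of the 3 values shown sits, is all that can be said of it.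

Compound 4, `CNc1cc(Oc2ccc(NC(=O)Nc3cccc(C(F)(F)F)c3)cc2)ncn1`, has not yet been measured. It arises from compound 1 by a single change, (trifluoromethyl in place of methyl on an aromatic carbon), on an aromatic carbon of the six-membered all-carbon ring, meta to a large group. For the measured compounds named here, no measured pair shows this change alone, so its size cannot be read off directly; compound 3 and compound 2, both bearing a trifluoromethyl there, sit well below compound 1, but each also carries other changes.

The author therefore expects a step to a clearly lower number, a 21-fold lower number from compound 1 to compound 4 (1.32 log units; beyond the scatter), from compound 1 to compound 4, with compound 4 estimated at 60 nM, between 15 nM and 250 nM.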

Compound 4, half-maximal inhibitory concentration: 40 nM
Estimate against measurement, compound 4: 1.5-fold (0.18 log units) above; the measured number falls inside the stated range.
By their numbers in this assay, from the lowest: compounds 3 and 4 (each within the scatter of the next); then compound 1. At a limit, below all of these: compound 2.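

Taken alone on the shared core, trifluoromethyl in place of methyl on this aromatic carbon gives a 32-fold lower number from compound 1 to compound 4 (1.50 log units; beyond the scatter), a large step. The earlier compounds shown here carried trifluoromethyl there only together with other changes, whereas compound 4 keeps the rest of compound 1 intact, so this step belongs to the exchange at this position and to nothing else. Compound 2 stands at a limit and not at a number in this assay, which leaves it without a measured place beside compound 4: the limit of <= 10 nM in this assay, at which 1 of the 4 values shown sits.

The two fluorines of compound 3 and the ring substituents of compound 2 cannot be read as steps of their own, as neither compound differs from compound 4 in one place only. The compounds shown also hold only methyl and trifluoromethyl on this aromatic carbon, leaving open whether a chlorine, a methoxy group or a nitrile there would give a number close to that of compound 4 or to that of compound 1.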